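The compounds below may be only part of what the source reports. "The series", "measured", "known", "first", "only" and "open" are said of these compounds alone.

In an assay on cells for inhibition of Amine oxidase [flavin-containing] B (Homo sapiens), read by spectrophotometry (on this read-out higher numbers stand for weaker inhibition and lower numbers for stronger inhibition), the measured compounds stand as follows:
compound 1 `Oc1ccccc1NC(=S)Nc1ccc2[nH]ccc2c1` gives 4000 nM;
compound 2 `COc1ccc(NC(=S)Nc2ccc3[nH]ccc3c2)cc1` gives 37000 nM;
compound 3 `S=C(Nc1ccc(Br)cc1)Nc1ccc2[nH]ccc2c1` gives 58000 nM.

Compound 2 thus holds the second highest of the three numbers; compound 3 is nearest, within the scatter, and compound 1 is furthest, beyond it. Compound 4 `CC(=O)Nc1ccc(NC(=S)Nc2ccc3[nH]ccc3c2)cc1` differs from compound 2 by acetamido in place of methoxy on an aromatic carbon. Going by the values given here, the only measured step that bears on this exchange is a 1.6-fold higher number from compound 2 to compound 3 (0.20 log units; within the scatter), which stayed within the scatter. Among the compounds with values here, no measured compound carries an acetamido group. The step from compound 2 to compound 4 is therefore expected to be small, a 1.6-fold higher number from compound 2 to compound 4 (0.21 log units; within the scatter), toward a somewhat higher number if anything. In this assay compound 4 is estimated at 60000 nM, with a range from 20000 nM to 200000 nM.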

Compound 4, half-maximal inhibitory concentration: 37000 nM
For compound 4 the middle estimate is 1.6-fold (0.21 log units) above the measured one; the range from low to high includes it.
By their numbers in this assay, from the lowest: compound 1; then compounds 2, 4 and 3 (each within the scatter of the next).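

In this assay, the place para to a large group has now carried methoxy, bromo and acetamido. Acetamido in place of methoxy gives no change at the digits printed from compound 2 to compound 4 (within the scatter), and acetamido in place of bromo gives a 1.6-fold lower number from compound 3 to compound 4 (0.20 log units; within the scatter), so among compounds 2, 3 and 4 neither the added heavy atoms nor the added hydrogen-bond donor of acetamido moves the number beyond the scatter. Nothing at hand explains this agreement. As far as these compounds go, whether an amine or a carboxylic acid on this carbon would stay within the scatter of these three remains open.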